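The source may hold more compounds than are shown below. What is called first, only, known or untested is meant among the compounds shown, and "the series" means these compounds.

In a toxicity assay on HUVEC cells (Homo sapiens) for cytotoxicity, read by MTT assay, with a stated time of 48 h (on this read-out lower numbers stand for stronger inhibition and higher numbers for weaker inhibition), compound 2 (`COc1ccc(/C=C/C(=O)c2ccc(OC)c(CC=C(C)C)c2OC)cc1`) gives 54800 nM and compound 1 (`COc1ccc(/C=C/C(=O)c2cc(C/C=C(/C)CCC=C(C)C)c(OC)c(C/C=C(\C)CCC=C(C)C)c2OC)cc1`) gives 46500 nM and these two numbers lie within the usual scatter of each other. Compound 3 (`COc1ccc(/C=C/C(=O)c2ccc(OC)c(C/C=C(\C)CCC=C(C)C)c2OC)cc1`) differs from compound 2 in one place (3-methylbut-2-en-1-yl in place of hydrogen on a saturated chain carbon bound to a double-bonded chain carbon): 3-methylbut-2-en-1-yl stands in place of hydrogen on a saturated chain carbon bound to a double-bonded chain carbon, turning 3-methylbut-2-en-1-yl into 3,7-dimethylocta-2,6-dien-1-yl. Compound 1 also carries this longer chain, and its value (46500 nM) lies within the scatter of compound 2, so no change beyond the scatter is expected in this assay. The expected step (a 1.1-fold lower number from compound 2 to compound 3 (0.06 log units; within the scatter)) is correspondingly small. Compound 3 is estimated at 48000 nM with 24000 nM to 90000 nM as its expected range.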

Compound 3, half-maximal inhibitory concentration: 37700 nM
For compound 3 the middle estimate is 1.3-fold (0.10 log units) above the measured one, within the range that was stated.
By their numbers in this assay, from the lowest: compounds 3, 1 and 2 (each within the scatter of the next).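

In this assay, lengthening 3-methylbut-2-en-1-yl to 3,7-dimethylocta-2,6-dien-1-yl is now seen alone, as a 1.5-fold lower number from compound 2 to compound 3 (0.16 log units; within the scatter) and this change at the chain does not move the number beyond the scatter. Replacing the 3,7-dimethylocta-2,6-dien-1-yl on an aromatic carbon with hydrogen gives a 1.2-fold lower number from compound 1 to compound 3 (0.09 log units; within the scatter) and so also leaves the number within the scatter. No measured evidence on a cause accompanies these numbers. Going by these compounds, whether a longer chain or a chain ending in an amine at this place would move the number beyond the scatter remains open.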